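A few compounds are considered here, and "the series" means these few. Any claim that something is new, unique, unknown or untested is made for them only; others in the source may bear on it.

Measured so far:
- compound 1, `CCC(C)(C)Cc1c[nH]c(CCc2ccc(-c3cccc(C)n3)cc2)n1`: 106 nM in a functional assay on HEK293 cells for agonist activity at Bombesin receptor subtype-3 (Mus musculus), read by luminescence and calcium flux, with a stated time of 10 min; a higher number here means that more compound is needed for the effect, a lower number that less compound is needed
- compound 2, `CCC(C)(C)Cc1c[nH]c(CCc2ccc(-c3cnsc3)cc2)n1`: 119 nM in this assay

Compound 2 holds the highest of the two numbers in this assay; its nearest neighbour is compound 1, and the step of a 1.1-fold higher number from compound 1 to compound 2 (0.05 log units; within the scatter) lies within the scatter, so the two compounds cannot be ordered on these numbers. Both share the same core and differ only in the aromatic group on the phenyl ring.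

Compound 3, `CCC(C)(C)Cc1c[nH]c(CCc2ccc(-n3cncn3)cc2)n1`, has not yet been measured in this assay. It differs from compound 2 in one place: 1H-1,2,4-triazol-1-yl in place of 1,2-thiazol-4-yl on an aromatic carbon.

Going by the values given here, the only step that bears on this change is the one from compound 1 to compound 2, where one five-membered heteroaryl replaced a six-membered one at the same place and the number moved by a 1.1-fold higher number from compound 1 to compound 2 (0.05 log units; within the scatter), within the scatter. Among the compounds with values here, that step suggests the site tolerates a change of ring, but the entering group here is linked through nitrogen and carries a third heteroatom, which no measured compound covers. A step of no more than modest size is therefore expected in this assay, with a slight lean toward a higher number.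

Compound 3 is estimated at 150 nM, range 55 nM to 450 nM, which means an expected step of a 1.3-fold higher number from compound 2 to compound 3 (0.10 log units; within the scatter).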

Compound 3, half-maximal effective concentration: 121 nM
Compound 3: middle estimate off by 1.2-fold (0.09 log units), on the high side; low and high end bracket the measured number.
By their numbers in this assay, from the lowest: compounds 1, 2 and 3 (each within the scatter of the next).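

At this place, on an aromatic carbon of a six-membered aromatic ring of carbon only, para to a large group, a 1.0-fold higher number from compound 2 to compound 3 (0.01 log units; within the scatter) is the step in this assay for 1H-1,2,4-triazol-1-yl in place of 1,2-thiazol-4-yl. The earlier compounds shown here covered only rings joined through carbon; this result adds a ring joined through nitrogen, with 3 hetero atoms and 3 hydrogen-bond acceptors in place of 2, and a 1.1-fold higher number from compound 1 to compound 3 (0.06 log units; within the scatter) shows that it also cannot be told apart from the six-membered 6-methylpyridin-2-yl group. No measurement accompanies these numbers that could explain why the three groups cannot be told apart.

Whether a carboxylic acid, an amine or a saturated ring such as morpholine at this place would give a step beyond the scatter remains open, as all three groups shown are aromatic rings. Also open is how far the number can move through this place at all: no step among compounds 1, 2 and 3 lies beyond the scatter, and the compounds shown identify no group that raises or lowers it.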